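Thioether aryl exchange in the benzamide branch

The source may hold more compounds than are shown below. What is called first, only, known or untested is meant among the compounds shown, and "the series" means these compounds.

Of the compounds shown here, three have been measured. Compound 1 `Nc1ccccc1NC(=O)c1ccc(CSc2ccc(Br)cc2)cc1` carries the amide directly on the aryl ring, whereas compound 2 `Nc1ccccc1NC(=O)/C=C/c1ccc(CSc2ccc(F)cc2)cc1` and compound 3 `Nc1ccccc1NC(=O)/C=C/c1ccc(CSc2ccc(Cl)cc2)cc1` carry it through a trans double bond. In a functional assay on HeLa cells (Homo sapiens) for inhibition, read by CCK-8 assay, with a stated time of 72 h, tested at 2 uM (a lower number here means less inhibition of growth, a higher number more inhibition of growth at the concentration tested), compound 1 gives 18.8%, the highest of the three values. Within the data shown here, compound 2 gives 7.09% and compound 3 gives 1.94%; the only one-place step among the measured compounds is a number 5.2 percentage points lower from compound 2 to compound 3 (within the scatter).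

Compound 4 `Nc1ccccc1NC(=O)c1ccc(CSc2cccc(F)c2)cc1` differs from compound 1 by 3-fluorophenyl in place of 4-bromophenyl on a sulfur. Among the measured compounds shown here, the step of a number 5.2 percentage points lower from compound 2 to compound 3 (within the scatter) is the only measured guide: it exchanges one halogen for another and stays within the scatter, but it belongs to the double-bond pair, and no measured pair isolates the change from 4-bromophenyl to 3-fluorophenyl. Resting on the within-scatter step a number 5.2 percentage points lower from compound 2 to compound 3 (within the scatter), the expected step is a number 4.8 percentage points lower from compound 1 to compound 4 (within the scatter), no change beyond the scatter or at most a small fall. Compound 4 is therefore expected at 14%, with a range from 4% to 25%.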

Compound 4, percent growth inhibition at one concentration: 22.5%
Compound 4: the middle estimate sits 8.5 percentage points below what was measured; measured number inside the range.
By their numbers in this assay, from the lowest: compounds 3 and 2 (each within the scatter of the next); then compounds 1 and 4 (each within the scatter of the next).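

In this assay, among these compounds, replacing 4-bromophenyl with 3-fluorophenyl on a sulfur gives a number 3.7 percentage points higher from compound 1 to compound 4 (within the scatter), the only step read at this position in the branch that carries the amide directly on the aryl ring. The halogen and its place on the phenyl ring change together here, and the pair still shows no shift beyond the scatter, so this position accepts this one double exchange without a clear change in growth inhibition at the concentration tested. No measurement in hand bears on the reason for this step.

The compounds shown leave open whether the identity of the halogen and its place on the ring would each matter if changed alone. They also leave open whether an amine or a carboxylic acid on the phenyl ring would move the value beyond the scatter.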